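Another group on the carbonyl carbon, same expectation

The source may report more compounds than this note shows. Statements on the series, on what has been measured and on what is new or still open speak of the compounds shown alone.

For the measured compounds named here, compound 2 `COC[C@@H]1CCCN1C(=O)[C@@H]1CCCN1c1nccc(Nc2ccccc2)n1` is one of two compounds measured in an assay on isolated protein for inhibition of vascular endothelial growth factor receptor 1 (Homo sapiens), read by HTRF, tested at 10 uM (a higher number here means more inhibition at the concentration tested (going by the name of the read-out), a lower number less inhibition), where compound 2 gives 1%. That is the lower of the two numbers, but only just: compound 1 `CN(CCCn1ccnc1)C(=O)[C@@H]1CCCN1c1nccc(Nc2ccccc2)n1` gives 4% in this assay, and the step of a number 3 percentage points lower from compound 1 to compound 2 (within the scatter) lies within the scatter, so the two cannot be told apart on these numbers. Compound 3 `CN(C)CC(C)(C)CNC(=O)[C@@H]1CCCN1c1nccc(Nc2ccccc2)n1` has not yet been measured. It differs from compound 2 at the carbonyl carbon where compound 1 and compound 2 already differ: (2-((dimethylamino)methyl)-2-methylpropyl)amino in place of 2-(methoxymethyl)pyrrolidin-1-yl on a carbonyl carbon. Going by the values given here, the only measured step that bears on this change is a number 3 percentage points lower from compound 1 to compound 2 (within the scatter), and it stayed within the scatter; exchanging one group on that carbonyl carbon for another made no discernible difference. With nothing else to go on, no step beyond the scatter is expected this time either, so the estimate means a number 2 percentage points higher from compound 2 to compound 3 (within the scatter). Compound 3 is therefore estimated at 3% in this assay, with a range from -5% to 12%.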

Compound 3, a percentage reported as inhibition, at one concentration (the size of the read-out at that concentration, not a potency): 12%
Compound 3: middle estimate off by 9 percentage points, on the low side, within the range that was stated.
By their numbers in this assay, from the lowest: compounds 2, 1 and 3 (each within the scatter of the next, the first and the last beyond it).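

In this assay the exchange on the carbonyl carbon gives a number 11 percentage points higher from compound 2 to compound 3 (beyond the scatter), the only step among these compounds that passes the scatter, so what sits at this place is not wholly without consequence for the read-out. The same (2-((dimethylamino)methyl)-2-methylpropyl)amino group set against (3-(1H-imidazol-1-yl)propyl)(methyl)amino gives a number 8 percentage points higher from compound 1 to compound 3 (within the scatter), which means the step can be read only against 2-(methoxymethyl)pyrrolidin-1-yl, and compound 1 cannot be separated from either of the other two. The effect is also small in absolute terms: compound 3 gives 12%, a read-out at a single concentration and not a potency.

No measurement at hand says what lies behind this step. The change removes a ring and brings in the amide hydrogen and a dimethylamino group all at once, so the compounds shown leave open which of these matters, and whether a longer chain ending in the same dimethylamino group, or a primary amine in its place, would move the number further.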